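Amide Variation on a Dimethoxy Core in Paw Edema

The source may hold more compounds than are shown below. What is called first, only, known or untested is meant among the compounds shown, and "the series" means these compounds.

Measured compounds:
compound 1 `COc1cc2c(cc1OC)C(CC(=O)N(C)C)CC2` gives 35.9%
compound 2 `CCCCCCNC(=O)CC1CCc2cc(OC)c(OC)cc21` gives 42.1%
compound 3 `COc1cc2c(cc1OC)C(CC(=O)NCc1ccccc1)CC2` gives 18.8%

In a functional assay on the whole organism (strain Wistar) for inhibition, with Rattus norvegicus as the target, read by paw edema, with stated times of 60 min and 4 h, at a dose of 100 mg/kg by the oral route (on this read-out higher numbers stand for more inhibition at the one dose given (going by the name of the read-out) and lower numbers for less inhibition), compound 1 stands second highest of the three numbers: the nearest is compound 2, with a number 6.2 percentage points higher from compound 1 to compound 2 (within the scatter), and the furthest is compound 3, with a number 17.1 percentage points lower from compound 1 to compound 3 (beyond the scatter). Compound 4 `COc1cc2c(cc1OC)C(CC(=O)N1CCNCC1)CC2` differs from compound 1 in one place, (piperazin-1-yl in place of dimethylamino on a carbonyl carbon). Both measured steps alter the same amide substituent of the shared core, one within the scatter and one beyond it, but neither introduces a ring amine, so they give no firm direction. A step of a number 0.9 percentage points lower from compound 1 to compound 4 (within the scatter) is expected, that is none beyond the scatter. Compound 4 is therefore estimated at 35%, between 20% and 50%.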

Compound 4, a percentage reported as inhibition, in the whole organism at one dose (the size of the read-out at that dose, not a potency): 40.6%
Compound 4: middle estimate off by 5.6 percentage points, on the low side; the range from low to high includes it.
By their numbers in this assay, from the lowest: compound 3; then compounds 1, 4 and 2 (each within the scatter of the next).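

In this assay, piperazin-1-yl on the carbonyl carbon brings in a six-membered non-aromatic ring and a hydrogen-bond donor, yet stays within the scatter of both dimethylamino (a number 4.7 percentage points higher from compound 1 to compound 4 (within the scatter)) and hexylamino (a number 1.5 percentage points lower from compound 2 to compound 4 (within the scatter)). Among the amides shown, only benzylamino stands apart, and piperazin-1-yl differs from it beyond the scatter (a number 21.8 percentage points higher from compound 3 to compound 4 (beyond the scatter)). Nothing available explains these numbers.

On these data alone, it remains open whether morpholin-4-yl would read like piperazin-1-yl. Also open, as far as these compounds go, is how a methyl group on the free ring nitrogen would change the number.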